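Swapping cyclohexyl for methylphenyl on the piperazine nitrogen

A few compounds are considered here, and "the series" means these few. Any claim that something is new, unique, unknown or untested is made for them only; others in the source may bear on it.

Compound 3 `CC(C(=O)NCc1ccc(C(F)(F)F)nc1N1CCN(C2CCCCC2)CC1)c1ccc(NS(C)(=O)=O)c(F)c1` gives 21.6 nM in a functional assay on CHO-K1 cells for antagonist activity at transient receptor potential cation channel subfamily V member 1 (Homo sapiens), read by FLIPR (a lower number here means a stronger inhibitor, a higher number a weaker inhibitor), the lowest of the three numbers, although its gap to compound 1 `CC(C(=O)NCc1ccc(C(F)(F)F)nc1Nc1ccc(F)cc1)c1ccc(NS(C)(=O)=O)c(F)c1`, which gives 39.2 nM, lies within the scatter; compound 2 `CC(C(=O)NCc1ccc(C(F)(F)F)nc1N1CCN(C)CC1)c1ccc(NS(C)(=O)=O)c(F)c1` gives 146 nM. Compound 4 `Cc1cccc(N2CCN(c3nc(C(F)(F)F)ccc3CNC(=O)C(C)c3ccc(NS(C)(=O)=O)c(F)c3)CC2)c1` differs from compound 3 by 3-methylphenyl in place of cyclohexyl on an amine nitrogen in a ring. The step that bears most on this change is a 6.8-fold lower number from compound 2 to compound 3 (0.83 log units; beyond the scatter), where a larger group on the same ring nitrogen went with a lower number. The step of a 1.8-fold lower number from compound 1 to compound 3 (0.26 log units; within the scatter) shows that an aromatic ring at this side of the core gave a number close to that of compound 3. A small step, a 1.2-fold higher number from compound 3 to compound 4 (0.06 log units; within the scatter), is therefore expected, staying within the scatter. Compound 4 is estimated at 25 nM, with a range from 8 nM to 80 nM.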

Compound 4, inhibition constant: 3.4 nM
Compound 4: middle estimate off by 7.4-fold (0.87 log units), on the high side; measured number below the stated range.
By their numbers in this assay, from the lowest: compound 4; then compounds 3 and 1 (each within the scatter of the next); then compound 2.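

Putting 3-methylphenyl in place of cyclohexyl on this ring nitrogen gives a 6.4-fold lower number from compound 3 to compound 4 (0.80 log units; beyond the scatter), so the kind of ring counts here, not only the presence of a six-membered ring. Against methyl, the same group gives a 43-fold lower number from compound 2 to compound 4 (1.63 log units; beyond the scatter), the largest step among these compounds. Nothing measured here explains why the number falls. The change brings in an aromatic ring and a methyl together, and the compounds shown do not separate the two. An unsubstituted phenyl would do that, while 4-methylphenyl would test where the methyl sits.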